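A few compounds are considered here, and "the series" means these few. Any claim that something is new, unique, unknown or untested is made for them only; others in the source may bear on it.

Compound 1, `Nc1scc(CN2CCN(c3cccc(C(F)(F)F)c3)CC2)c1C(=O)c1ccc(Cl)cc1`, is the starting point of this comparison. In an assay on CHO cells for displacement of a labelled ligand from adenosine receptor A3 (Homo sapiens), read by scintillation counting, with a stated time of 120 min, tested at 10 uM (on this read-out lower numbers stand for less inhibition and higher numbers for more inhibition at the one concentration tested (going by the name of the read-out)), compound 1 gives 0%, the lowest of the two numbers measured, and its nearest neighbour is compound 2, `Nc1scc(CN2CCN(c3ccc(F)c(F)c3)CC2)c1C(=O)c1ccc(Cl)cc1`, which in this assay gives 1%. Going by the values given here, the one measured step, a number 1 percentage points higher from compound 1 to compound 2 (within the scatter), replaces the aryl group on the ring nitrogen and stays within the scatter. Compound 3, `Nc1scc(CN2CCN(c3c(Cl)cccc3Cl)CC2)c1C(=O)c1ccc(Cl)cc1`, differs from compound 1 by 2,6-dichlorophenyl in place of 3-(trifluoromethyl)phenyl on an amine nitrogen in a ring. The step from compound 1 to compound 2 is the only one that bears on it, since it also exchanges the aryl group on that ring nitrogen, and it was small. Compound 3 is therefore expected to show a step of a number 3 percentage points higher from compound 1 to compound 3 (within the scatter) in this assay, that is, none beyond the scatter. For compound 3 the estimate is 3%, with a range from 0% to 15%.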

Compound 3, a percentage reported as inhibition, at one concentration (the size of the read-out at that concentration, not a potency): 1%
Compound 3: the middle estimate sits 2 percentage points above what was measured, within the range that was stated.
By their numbers in this assay, from the lowest: compounds 1, 2 and 3 (each within the scatter of the next).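

In this assay, 2,6-dichlorophenyl on the amine nitrogen in the ring gives a step of a number 1 percentage points higher from compound 1 to compound 3 (within the scatter) against 3-(trifluoromethyl)phenyl, and a step of no change at the digits printed from compound 2 to compound 3 (within the scatter) against 3,4-difluorophenyl. The earlier pair offered a single exchange at this position, whereas three aryl groups now compare, and the two chlorines of the new group leave the number within the scatter of both others. No measured evidence accounts for this flat result.

The compounds shown leave open whether anything other than a substituted phenyl on that ring nitrogen, such as a carboxylic acid, an amine or a longer chain, would move the number beyond the scatter. They also leave open whether another group in place of the 4-chlorophenyl on the carbonyl would do so.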